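A Halogen Removed From the Fused Ring

This account rests on a few compounds, and the source may have more. Where it says the series, first, only, none or still open, it means among the compounds named here.

In a functional assay on A549 cells (Homo sapiens) for cytotoxicity, read by MTT assay, with a stated time of 72 h (on this read-out higher numbers stand for weaker inhibition and lower numbers for stronger inhibition), compound 2 `O=C(Nc1ccc(-n2ncc3c(F)cccc32)cc1)Nc1ccc(Cl)c(C(F)(F)F)c1` gives 3800 nM. Compound 1 `O=C(Nc1ccc(-n2ncc3c(Cl)cccc32)cc1)Nc1ccc(Cl)c(C(F)(F)F)c1` gives 3100 nM, and the two sit within the scatter of each other: a 1.2-fold higher number from compound 1 to compound 2 (0.09 log units; within the scatter). Compound 3 `O=C(Nc1ccc(-n2ncc3ccccc32)cc1)Nc1ccc(Cl)c(C(F)(F)F)c1` carries the shared core with hydrogen in place of fluoro on an aromatic carbon. Within the data shown here, only the step from compound 1 to compound 2 bears on this change, and it was small, so a change at that position looks unimportant so far; no more is known about removing the group entirely. The expected step is therefore a 1.2-fold higher number from compound 2 to compound 3 (0.07 log units; within the scatter), at most slightly toward weaker inhibition. Compound 3 is estimated at 4500 nM, between 2000 nM and 10000 nM.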

Compound 3, half-maximal inhibitory concentration: 9900 nM
The estimate for compound 3 lay 2.2-fold (0.34 log units) below the measured number, within the range that was stated.
By their numbers in this assay, from the lowest: compounds 1 and 2 (each within the scatter of the next); then compound 3.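

Exchanging one halogen for the other barely moved the number, but removing the halogen altogether does register in this assay: hydrogen in place of fluoro gives a 2.6-fold higher number from compound 2 to compound 3 (0.42 log units; beyond the scatter) and hydrogen in place of chloro gives a 3.2-fold higher number from compound 1 to compound 3 (0.50 log units; beyond the scatter), both modest. On this aromatic carbon, then, either halogen goes with stronger inhibition than hydrogen, though the two halogens cannot be told apart. Nothing here shows why.

On these data alone, it remains open whether a non-halogen group on this carbon, such as an amine or a methoxy group, would match the halogens or fall back toward hydrogen.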